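Compound 3 and the tert-butyl series: amino acid substitution

The source may hold more compounds than are shown below. What is called first, only, known or untested is meant among the compounds shown, and "the series" means these compounds.

Measured in a functional assay on Fem-X cells (Homo sapiens) for cytotoxicity, read by MTT assay, with a stated time of 72 h; a lower number here means a stronger inhibitor, a higher number a weaker inhibitor:
- compound 1 `CC(C)(C)C1=CC(=O)C=C(NCCC(=O)O)C1=O`: 28400 nM
- compound 2 `CC(C)(C)C1=CC(=O)C=CC1=O`: 41600 nM

For the measured compounds named here, compound 2 gives 41600 nM, which lies within the scatter of the only other measured value, that of compound 1. Compound 3 `C[C@H](NC1=CC(=O)C=C(C(C)(C)C)C1=O)C(=O)O` carries (1-carboxyethyl)amino in place of hydrogen on a double-bonded ring carbon of compound 2 ((1-carboxyethyl)amino in place of hydrogen on a double-bonded ring carbon).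

Going by the values given here, one measured step bears on this change: a 1.5-fold higher number from compound 1 to compound 2 (0.17 log units; within the scatter). That step puts hydrogen in place of (2-carboxyethyl)amino, and it stays within the scatter. Among the compounds with values here, no measurement yet covers the (1-carboxyethyl)amino group itself. A step beyond the scatter in this assay is therefore not expected, and any shift should be toward a lower number, if it appears at all. The expected change is a 1.4-fold lower number from compound 2 to compound 3 (0.14 log units; within the scatter). For compound 3 the estimated value is 30000 nM, with an expected range of 14000 nM to 62000 nM.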

Compound 3, half-maximal inhibitory concentration: 20100 nM
Estimate against measurement, compound 3: 1.5-fold (0.17 log units) above; low and high end bracket the measured number.
By their numbers in this assay, from the lowest: compounds 3, 1 and 2 (each within the scatter of the next, the first and the last beyond it).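

In this assay, for the compounds shown here, (1-carboxyethyl)amino on the double-bonded ring carbon gives a 2.1-fold lower number from compound 2 to compound 3 (0.32 log units; beyond the scatter) and is the first substitution at this position to pass beyond the scatter, though only modestly; the (2-carboxyethyl)amino group of compound 1 stays within the scatter of hydrogen. The two chains themselves remain indistinguishable on the amine nitrogen, with 1-carboxyethyl in place of 2-carboxyethyl giving a 1.4-fold lower number from compound 1 to compound 3 (0.15 log units; within the scatter) and so no preference between them. Nothing available here explains the step from hydrogen to the amino acid group.

Still open, from the compounds shown here alone, is whether the carboxylic acid is needed, which a simple alkyl amine or a methyl ester at this position would test. Also open, going by these compounds, are the effect of a longer chain on the amine nitrogen and of the opposite configuration at the defined stereocentre of the 1-carboxyethyl group.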